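Changing the Amide Aryl Group: Compound 1 to Compound 4

This account rests on a few compounds, and the source may have more. Where it says the series, first, only, none or still open, it means among the compounds named here.

Measured compounds:
compound 1, `O=C(Nc1cccc(-c2oc3cc(-c4ccc(F)cc4)ccc3c(=O)c2O)c1)c1ccccc1F`, gives 7240 nM in a functional assay on MDA-MB-231 cells (Homo sapiens) for antiproliferative activity, read by CCK-8 assay, with a stated time of 72 h; on this read-out lower numbers stand for stronger inhibition and higher numbers for weaker inhibition
compound 2, `O=C(Nc1cccc(-c2oc3cc(-c4ccc(F)cc4)ccc3c(=O)c2O)c1)c1cccc(F)c1`, gives 2510 nM in this assay
compound 3, `O=C(Nc1cccc(-c2oc3cc(-c4ccc(F)cc4)ccc3c(=O)c2O)c1)c1cc(F)cc(F)c1`, gives 2440 nM in this assay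

All three share the same core and differ only in the aryl group attached to the amide carbonyl. Compound 1 gives the highest number of the three in this assay; its nearest neighbour is compound 2 and its furthest is compound 3.

Compound 4, `O=C(Nc1cccc(-c2oc3cc(-c4ccc(F)cc4)ccc3c(=O)c2O)c1)c1ccc(-c2ccccc2)cc1`, has not yet been measured. It differs from compound 1 in one place: 4-phenylphenyl in place of 2-fluorophenyl on a carbonyl carbon.

Within the data shown here, two measured steps bear on this change, since both also exchange the 2-fluorophenyl on the carbonyl carbon for a different aryl group: a 2.9-fold lower number from compound 1 to compound 2 (0.46 log units; beyond the scatter) and a 3.0-fold lower number from compound 1 to compound 3 (0.47 log units; beyond the scatter). Between those two products the step of a 1.0-fold lower number from compound 2 to compound 3 (0.01 log units; within the scatter) is within the scatter. Among the measured compounds shown here, none of the measured compounds carries a 4-phenylphenyl group, so the new group itself is untested here. Because leaving the 2-fluorophenyl gave lower numbers in a 2.9-fold lower number from compound 1 to compound 2 (0.46 log units; beyond the scatter) and a 3.0-fold lower number from compound 1 to compound 3 (0.47 log units; beyond the scatter), a modest step to a lower number is expected for compound 4, a 2.4-fold lower number from compound 1 to compound 4 (0.38 log units; beyond the scatter). Compound 4 is therefore estimated at 3000 nM in this assay, with a range from 1000 nM to 9000 nM.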

Compound 4, half-maximal inhibitory concentration: 63200 nM
Compound 4: the middle estimate sits 21-fold (1.32 log units) below what was measured; the whole stated range lies below it.
By their numbers in this assay, from the lowest: compounds 3 and 2 (each within the scatter of the next); then compound 1; then compound 4.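

This position does not simply reward moving away from the 2-fluorophenyl group: in this assay, the 4-phenylphenyl group shifts the result in the opposite direction from the two other fluorinated aryl groups, with an 8.7-fold higher number from compound 1 to compound 4 (0.94 log units; beyond the scatter). Set against the two lowest numbers in the series, the rise is larger still, at a 25-fold higher number from compound 2 to compound 4 (1.40 log units; beyond the scatter) and a 26-fold higher number from compound 3 to compound 4 (1.41 log units; beyond the scatter), so the aryl group on this carbonyl carbon can move the read-out over a far wider span than the three fluorinated compounds alone revealed. Nothing measured here accounts for the much weaker inhibition seen with this two-ring group.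

From the compounds shown here alone, it remains open whether the rise belongs to the presence of a second phenyl ring or to where that ring is attached, a question that 3-phenylphenyl on the same carbonyl carbon could help to settle. Also open, going by these compounds, is how a single-ring group such as 4-methoxyphenyl or pyridyl, or a non-aromatic group such as cyclohexyl, would read in this assay.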